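The compounds below may be only part of what the source reports. "The series", "measured", "known", "first", "only" and "open" are said of these compounds alone.

Series notes. In a functional assay on A549 cells (Homo sapiens) for antiproliferative activity, read by MTT assay, with a stated time of 48 h (on this read-out higher numbers stand for weaker inhibition and lower numbers for stronger inhibition), compound 1 (`COc1ccc2c(/C=C/C(=O)c3cc(N)c(OC)c(OC)c3)c[nH]c2c1`) gives 193 nM and compound 2 (`COc1ccc2c(/C=C/C(=O)c3cc(N)c(OC)c(OC)c3)cn(C)c2c1`) gives 106 nM. Among the compounds with values here, compound 2 holds the lower of only two numbers, but the gap lies within the scatter, so the two compounds are not separated.

The next compound, compound 3 (`COc1cc(C(=O)/C=C/c2cn(C)c3ccccc23)cc(N)c1OC`), differs from compound 2 by hydrogen in place of methoxy on an aromatic carbon. That carbon belongs to a six-membered aromatic ring of carbon only, part of a fused or bridged system of two rings.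

Within the data shown here, the sole measured step is a 1.8-fold lower number from compound 1 to compound 2 (0.26 log units; within the scatter), with methyl in place of hydrogen on an aromatic nitrogen. It is a different change, and it stays within the scatter. Among the measured compounds shown here, no measured step removes a methoxy, so the data give no size or direction for this one. In this assay a step beyond the scatter is therefore not expected, only a slight lean to a higher number, and the range is kept wide. The expected step is a 1.7-fold higher number from compound 2 to compound 3 (0.23 log units; within the scatter). For compound 3 the estimated value is 180 nM, with an expected range of 60 nM to 600 nM.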

Compound 3, half-maximal inhibitory concentration: 498 nM
The estimate for compound 3 lay 2.8-fold (0.44 log units) below the measured number, within the range that was stated.
By their numbers in this assay, from the lowest: compounds 2 and 1 (each within the scatter of the next); then compound 3.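

In this assay, within the data shown here, the methoxy on an aromatic carbon of the six-membered aromatic ring of carbon only, part of a fused or bridged system of two rings, gives the first step beyond the scatter: a 4.7-fold higher number from compound 2 to compound 3 (0.67 log units; beyond the scatter), so hydrogen in place of methoxy at this position goes with weaker inhibition in this pair. Among these compounds, the only earlier step, a 1.8-fold lower number from compound 1 to compound 2 (0.26 log units; within the scatter), stayed within the scatter and left open whether any single change on this part of the core could separate two compounds, whereas this position now shows that one can. Nothing available bears on why the number moves at this position, and the result stands as an observation on this one pair.

The compounds shown leave open whether hydroxy, ethoxy or chlorine on this carbon would stay with compound 2 or fall with compound 3, and so whether the methoxy itself matters or any group other than hydrogen would serve. Also open, going by these compounds, is whether the same replacement would give a step of similar size on the core of compound 1, with hydrogen on the aromatic nitrogen.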